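Nitro to butoxy: working from limits only

The source may report more compounds than this note shows. Statements on the series, on what has been measured and on what is new or still open speak of the compounds shown alone.

In a functional assay on MT4 cells (Homo sapiens) for cytotoxicity, read by MTT assay (on this read-out higher numbers stand for lower toxicity in this test and lower numbers for higher toxicity in this test), compound 1 (`Cc1c(O)nc(SCc2ccc([N+](=O)[O-])cc2)nc1Cc1c(Cl)cccc1Cl`) gives > 58000 nM, which is a limit. Compound 2 (`Cc1c(O)nc(SCc2cccc(C#N)c2)nc1Cc1c(Cl)cccc1Cl`) gives > 60000 nM, also a limit. Compound 3 (`Cc1c(O)nc(SCc2cccc(F)c2)nc1Cc1c(Cl)cccc1Cl`) gives > 61000 nM, again a limit. The starting point for the next step is therefore a limit and not a number.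

Compound 4 (`CCCCOc1ccc(CSc2nc(O)c(C)c(Cc3c(Cl)cccc3Cl)n2)cc1`) carries butoxy in place of nitro on an aromatic carbon, para to a large group: butoxy in place of nitro on an aromatic carbon.

The measured steps that bear on this change are a step that the two limits leave unreadable from compound 1 to compound 2 and a step that the two limits leave unreadable from compound 1 to compound 3. The third is a step that the two limits leave unreadable from compound 2 to compound 3. None of them has a readable size, and none introduces butoxy, so the series offers only weak guidance. A modest move toward higher toxicity in this assay is assumed as a cautious expectation, and another limit remains quite possible. The expected change is an at least 1.2-fold lower number from compound 1 to compound 4 (0.11 log units; that floor lies within the scatter). For compound 4 the estimated value is 45000 nM, with an expected range of 15000 nM to 90000 nM.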

Compound 4, half-maximal cytotoxic concentration: 3100 nM
For compound 4 the middle estimate is 15-fold (1.16 log units) above the measured one; the whole stated range lies above it.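

In this assay the change from nitro to butoxy on an aromatic carbon, para to a large group, gives an at least 18-fold lower number from compound 1 to compound 4 (1.27 log units; beyond the scatter), so a substituent at this place can move the read-out toward higher toxicity in this test. That size is only a floor, as compound 1 stands at a limit: the limit of > 58000 nM in this assay, at which 1 of the 4 values shown sits. The steps among compound 1, compound 2 and compound 3 cannot be read, which leaves compound 4 as the only compound shown with a measured number.

The compounds shown leave open whether the step follows the ether oxygen of butoxy or the length of its chain. A methoxy group, a plain butyl chain or a longer alkoxy chain such as hexyloxy at the same place would separate the two.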